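The source may hold more compounds than are shown below. What is called first, only, known or untested is meant among the compounds shown, and "the series" means these compounds.

Measured compounds in a functional assay on the whole organism (strain Wistar) for inhibition, with Rattus norvegicus as the target, read by paw edema, with stated times of 60 min and 24 h, at a dose of 100 mg/kg by the oral route; on this read-out lower numbers stand for less inhibition and higher numbers for more inhibition at the one dose given (going by the name of the read-out):
- compound 1 `COc1cc2c(cc1OC)C(CC(=O)O)CC2`: 26.7%
- compound 2 `COc1cc2c(cc1OC)C(CC(=O)NC(C)C)CC2`: 30%
- compound 3 `COc1cc2c(cc1OC)C(CC(=O)N1CCCC1)CC2`: 33.3%

Compound 3 holds the highest of the three numbers, yet neither gap reaches beyond the scatter: a number 3.3 percentage points higher from compound 2 to compound 3 (within the scatter) and a number 6.6 percentage points higher from compound 1 to compound 3 (within the scatter). The next step is to compound 4 `COc1cc2c(cc1OC)C(CC(=O)N1CCCCC1)CC2`; the change is piperidin-1-yl in place of pyrrolidin-1-yl on a carbonyl carbon. Within the data shown here, the steps that bear on it all sit on the same carbonyl carbon: a number 3.3 percentage points higher from compound 1 to compound 2 (within the scatter), a number 6.6 percentage points higher from compound 1 to compound 3 (within the scatter) and a number 3.3 percentage points higher from compound 2 to compound 3 (within the scatter), each within the scatter. Nothing in these numbers separates hydroxy, isopropylamino and pyrrolidin-1-yl on that carbon, so compound 4 is expected to show no step beyond the scatter, a number 1.7 percentage points higher from compound 3 to compound 4 (within the scatter). The estimate for compound 4 is 35%, with a range from 25% to 45%.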

Compound 4, a percentage reported as inhibition, in the whole organism at one dose (the size of the read-out at that dose, not a potency): 40%
Compound 4: the middle estimate sits 5 percentage points below what was measured; low and high end bracket the measured number.
By their numbers in this assay, from the lowest: compounds 1, 2, 3 and 4 (each within the scatter of the next, the first and the last beyond it).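

Among these compounds, the step of a number 13.3 percentage points higher from compound 1 to compound 4 (beyond the scatter) is the first to clear the scatter, with piperidin-1-yl on the carbonyl carbon set against hydroxy. Among the amine groups, the picture stays unresolved: a number 6.7 percentage points higher from compound 3 to compound 4 (within the scatter) and a number 10 percentage points higher from compound 2 to compound 4 (within the scatter) leave piperidin-1-yl unseparated from either pyrrolidin-1-yl or isopropylamino. Nothing available explains the gain over hydroxy. Still open, going by these compounds, is how azepan-1-yl or morpholin-4-yl would read on the same carbon. With one dose only, the numbers also leave potency open.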